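Urea and thiourea pair: cyanophenyl for chlorophenyl

The source may report more compounds than this note shows. Statements on the series, on what has been measured and on what is new or still open speak of the compounds shown alone.

Measured so far in an assay on cells for inhibition of Indoleamine 2,3-dioxygenase 1 (Homo sapiens); a lower number here means a stronger inhibitor, a higher number a weaker inhibitor:
compound 1 `N#Cc1ccc(NC(=O)NCc2cnc3scc(C#CC4CC4)n23)cc1` gives 102 nM
compound 2 `O=C(NCc1cnc2scc(C#CC3CC3)n12)Nc1cccc(Cl)c1` gives 42 nM
compound 3 `S=C(NCc1cnc2scc(C#CC3CC3)n12)Nc1cccc(Cl)c1` gives 27.6 nM

Compound 4 `N#Cc1ccc(NC(=S)NCc2cnc3scc(C#CC4CC4)n23)cc1` is not yet measured. It arises from compound 3 by 4-cyanophenyl in place of 3-chlorophenyl on an amide-type nitrogen. The same kind of change, (4-cyanophenyl in place of 3-chlorophenyl on an amide-type nitrogen), has already been made between measured compounds, the place differing only in that the nitrogen's other neighbour is a carbonyl carbon there and a thiocarbonyl carbon here; it gave a 2.4-fold higher number from compound 2 to compound 1 (0.39 log units; beyond the scatter). How the cores of compound 2 and compound 3 differ is not broken down here.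

For compound 4 a step of about the same size is expected, a 2.4-fold higher number from compound 3 to compound 4 (0.37 log units; beyond the scatter), resting on the earlier step of a 2.4-fold higher number from compound 2 to compound 1 (0.39 log units; beyond the scatter) and on compound 3 at 27.6 nM. Compound 4 is thus estimated at 65 nM in this assay, with a likely range of 35 nM to 130 nM.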

Compound 4, half-maximal inhibitory concentration: 16.4 nM
Compound 4: middle estimate off by 4.0-fold (0.60 log units), on the high side; measured number outside the range, below it.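

On the thiocarbonyl core in this assay, 4-cyanophenyl in place of 3-chlorophenyl gives a 1.7-fold lower number from compound 3 to compound 4 (0.23 log units; within the scatter), so compound 3 and compound 4 cannot be told apart. The change does not carry over as one fixed step from the carbonyl core to the thiocarbonyl core: the same change on two cores in this assay, a 2.4-fold higher number (0.39 log units; beyond the scatter) from compound 2 to compound 1 and a 1.7-fold lower number (0.23 log units; within the scatter) from compound 3 to compound 4, 4.1-fold (0.61 log units) apart, beyond the scatter of two such steps This shows that, for these two pairs, the step depends on the core, but one comparison does not show a general rule for thiocarbonyl compounds or explain the gap.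

Still open, going by these compounds, is whether the two cores also part ways with other groups on that nitrogen, such as a phenyl ring carrying a methoxy group or a carboxylic acid.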